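This account rests on a few compounds, and the source may have more. Where it says the series, first, only, none or still open, it means among the compounds named here.

Measured so far:
compound 1 `CNC(=O)c1cc(C(=O)NC2CCC2)cn(Cc2ccncc2)c1=O` — 1.7
compound 2 `CNC(=O)c1cc(C(=O)NC2CC2)cn(Cc2cccc(OC)c2)c1=O` — 3

In a physicochemical assay for lipophilicity, at pH 7.4 (on this read-out lower numbers stand for lower lipophilicity and higher numbers for higher lipophilicity), compound 1 gives 1.7, the lowest of the two numbers. Compound 2 gives 3, a number that lies beyond the scatter above compound 1. Compound 3 `CNC(=O)c1cc(C(=O)NC2CCC2)cn(Cc2cccc(NC)c2)c1=O` has not been measured; it differs from compound 1 in one place: 3-(methylamino)phenyl in place of pyridin-4-yl on a saturated chain carbon bound to an aromatic nitrogen. Among the compounds with values here, no step between measured compounds connects these two, so the expectation rests on the change alone. A rise in this assay well beyond the scatter is expected, a number 1.20 log units higher from compound 1 to compound 3 (beyond the scatter). Compound 3 is therefore estimated at 2.9, within a range from 2.4 to 3.4.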

Compound 3, distribution coefficient: 3.6
Compound 3: middle estimate off by 0.70 log units, on the low side; measured number above the stated range.
By their numbers in this assay, from the lowest: compound 1; then compound 2; then compound 3.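

In this assay, within the data shown here, the only step that can be read at this position is a number 1.90 log units higher from compound 1 to compound 3 (beyond the scatter) on going from pyridin-4-yl to 3-(methylamino)phenyl on a saturated chain carbon bound to an aromatic nitrogen. The earlier compounds shown here offered no such comparison, since they differ in more than one place. This single change, with the rest of the core of compound 1 held constant, moves the read-out by a large amount. Still open, going by these compounds, is how the step divides between replacing the ring and adding methylamino, which a plain phenyl or a primary amine in place of methylamino would address. No measurement shown accounts for the size of the step.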